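Series notes: second chlorine on the aryl group of compound 3

The compounds below may be only part of what the source reports. "The series", "measured", "known", "first", "only" and "open" are said of these compounds alone.

Compound 1 `O=C(/C=C\c1ccccc1O)N1N=C(c2ccncc2)OC1c1c[nH]c2ccccc12` gives > 30 ug/mL in an ADME assay on PANC-1 cells (Homo sapiens) for cytotoxicity, read by MTT assay, with a stated time of 48 h (a lower number here means a stronger inhibitor of growth, a higher number a weaker inhibitor of growth), a limit of the assay.
Compound 2 `O=C(/C=C\c1cccc(O)c1)N1N=C(c2ccncc2)OC1c1c[nH]c2ccccc12` gives > 30 ug/mL in this assay, a limit of the assay.
Compound 3 `O=C(/C=C\c1ccccc1Cl)N1N=C(c2ccncc2)OC1c1c[nH]c2ccccc12` gives > 30 ug/mL in this assay, a limit of the assay.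

Compound 3 thus stands at the assay limit, together with the other two, as the limit of > 30 ug/mL in this assay, at which 3 of the 3 values shown sit, records. Compound 4 `O=C(/C=C/c1c(Cl)cccc1Cl)N1N=C(c2ccncc2)OC1c1c[nH]c2ccccc12` differs from compound 3 by 2-(2,6-dichlorophenyl)ethenyl in place of 2-(2-chlorophenyl)ethenyl on a carbonyl carbon. The measured steps that touch compound 3 are a step that the two limits leave unreadable from compound 1 to compound 3 and a step that the two limits leave unreadable from compound 2 to compound 3, and the remaining step is a step that the two limits leave unreadable from compound 1 to compound 2; none of them has a readable size, and none involves a second chlorine. No step beyond the scatter can therefore be expected from compound 3 to compound 4, and the estimated step that the limit leaves unreadable from compound 3 to compound 4 carries that expectation. For compound 4 the expected value is 40 ug/mL, within an estimated range of 15 ug/mL to 120 ug/mL, most likely reported again as a limit.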

Compound 4, concentration for 50% growth inhibition: > 30 ug/mL
Compound 4 ended at the assay's limit; the forecaster's own chance of this, stated with the estimate: 75%; the middle value lies beyond the limit too.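

In this assay, among the compounds shown here, compound 4 gives > 30 ug/mL, a limit of the assay, so no step between it and compound 1, compound 2 or compound 3 can be read. The compounds shown leave open whether any aryl group on the ethenyl chain gives a readable value.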